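The compounds below may be only part of what the source reports. "The series", "measured", "known", "first", "only" and "open" are said of these compounds alone.

Going by the values given here, compound 2 `Cc1cc(C(=O)O)nn1Cc1cc(Br)ccc1OCc1cccc(Cl)c1` stands with the higher of the two numbers measured so far: in a functional assay on CHO-K1 cells for antagonist activity at prostaglandin E2 receptor EP1 subtype (Homo sapiens), read by FLIPR (a lower number here means a stronger inhibitor, a higher number a weaker inhibitor), compound 2 gives 427 nM, while compound 1 `Cc1cc(C(=O)O)nn1Cc1cc(Br)ccc1OCc1c(F)cccc1F` gives 105 nM. Among the compounds with values here, the only measured step, a 4.1-fold higher number from compound 1 to compound 2 (0.61 log units; beyond the scatter), exchanges the whole substituted ring carried on the oxygen attached to the aromatic ring of the shared core. Compound 3 `Cc1cc(C(=O)O)nn1Cc1cc(Br)ccc1OCc1cccc(C(F)(F)F)c1` keeps that ring and alters a single group on it: trifluoromethyl in place of chloro on an aromatic carbon. Within the data shown here, no measured pair sets chloro against trifluoromethyl on an aromatic carbon, so the one step available speaks to this change only indirectly, and nothing in the data points to a shift in either direction beyond the scatter. Compound 3 is therefore expected to show a step of a 1.1-fold lower number from compound 2 to compound 3 (0.03 log units; within the scatter). The estimate for compound 3 in this assay is 400 nM, with a range from 140 nM to 1200 nM.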

Compound 3, inhibition constant: 1100 nM
For compound 3 the middle estimate is 2.8-fold (0.44 log units) below the measured one; the range from low to high includes it.
By their numbers in this assay, from the lowest: compound 1; then compound 2; then compound 3.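

In this assay, trifluoromethyl in place of chloro on this aromatic carbon gives a 2.6-fold higher number from compound 2 to compound 3 (0.41 log units; beyond the scatter), a step beyond the scatter. The earlier step exchanged the whole substituted ring, so it could not show whether a single group on that ring matters by itself; this step shows that it does, since everything else in the molecule stays the same. No measurement here bears on the reason for this rise.

As far as these compounds go, whether a nitrile, a methoxy group or a plain hydrogen at this place would give a lower number or a still higher one remains open. Also open, from the compounds shown here alone, is whether the same exchange of chloro for trifluoromethyl would give a step of similar size on a ring carrying other groups.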